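The source may hold more compounds than are shown below. What is called first, only, known or untested is meant among the compounds shown, and "the series" means these compounds.

Measured in a physicochemical assay for lipophilicity; on this read-out lower numbers stand for lower lipophilicity and higher numbers for higher lipophilicity:

- compound 1 `CC(=O)NC(CCc1ccc(C#C[Si](C)(C)C)cc1)(COC(C)=O)COC(C)=O` gives 4.07
- compound 2 `CC(=O)NC(CCc1ccc(C#CC#C[Si](C)(C)C)cc1)(COC(C)=O)COC(C)=O` gives 4.97

Compound 2 stands highest of the two, and its 4.97 lies beyond the scatter from compound 1. The next compound is compound 3 `CC(=O)NC(CCc1ccc(C#CC#CC#C[Si](C)(C)C)cc1)(COC(C)=O)COC(C)=O`, which changes the group on a triple-bonded carbon: a group of 6 heavy atoms (5 carbon, 1 silicon; no ring) in place of a group of 4 heavy atoms (3 carbon, 1 silicon; no ring), on a triple-bonded carbon. Going by the values given here, only one measured step bears on this, a number 0.90 log units higher from compound 1 to compound 2 (beyond the scatter), where a group of 6 heavy atoms also replaced a group of 4 heavy atoms on a triple-bonded carbon. One step is thin evidence, but a rise of similar size is expected in this assay. The expected step is a number 0.83 log units higher from compound 2 to compound 3 (beyond the scatter). For compound 3 the estimated value is 5.8, with an expected range from 5.3 to 6.4.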

Compound 3, partition coefficient: 5.9
For compound 3 the middle estimate is 0.10 log units below the measured one; the range from low to high includes it.
By their numbers in this assay, from the lowest: compound 1; then compound 2; then compound 3.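

In this assay the same change on a triple-bonded carbon, a group of 6 heavy atoms in place of a group of 4 heavy atoms, now gives a second step (a number 0.93 log units higher from compound 2 to compound 3 (beyond the scatter)) of much the same size as the first (a number 0.90 log units higher from compound 1 to compound 2 (beyond the scatter)), so the first step was no one-off. Together the two steps add up to a number 1.83 log units higher from compound 1 to compound 3 (beyond the scatter) and no compound of the three goes against this steady climb. Nothing measured here explains the rise. A still longer chain of triple bonds might continue the climb or break it, and an amine or a carboxylic acid on the same triple-bonded carbon remains an open case.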